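A methyl for a fluoro at the assay limit

This account rests on a few compounds, and the source may have more. Where it says the series, first, only, none or still open, it means among the compounds named here.

Of the compounds shown here, three sharing one core have been read in an ADME assay on L6 cells (Rattus norvegicus) for cytotoxicity, read by resazurin assay, with a stated time of 72 h; on this read-out lower numbers stand for stronger inhibition and higher numbers for weaker inhibition. Compound 1 `CSc1ccc(-c2noc(CN3N=N[C@@H]4C(=O)N(c5ccccc5)C(=O)[C@@H]43)n2)cc1`, which carries methylsulfanyl, gives > 100 ug/mL, a limit of the assay and not a number. Compound 2 `COc1ccc(-c2noc(CN3N=N[C@@H]4C(=O)N(c5ccccc5)C(=O)[C@@H]43)n2)cc1`, which carries methoxy, gives > 100 ug/mL, again a limit. Compound 3 `O=C1[C@H]2N=NN(Cc3nc(-c4ccc(F)cc4)no3)[C@H]2C(=O)N1c1ccccc1`, which carries fluoro, gives > 100 ug/mL, also a limit. It therefore stands with the other two, and the record so far is the limit of > 100 ug/mL in this assay, at which 3 of the 3 values shown sit.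

Compound 4 `Cc1ccc(-c2noc(CN3N=N[C@@H]4C(=O)N(c5ccccc5)C(=O)[C@@H]43)n2)cc1` differs from compound 3 in one place, on an aromatic carbon para to a large group, with methyl in place of fluoro (methyl in place of fluoro on an aromatic carbon). Three measured exchanges at that carbon bear on this change: a step that the two limits leave unreadable from compound 1 to compound 3, a step that the two limits leave unreadable from compound 2 to compound 3 and a step that the two limits leave unreadable from compound 1 to compound 2. No size can be taken from any of them, yet none of the three groups brought a reading off the limit. No step beyond the scatter is therefore expected in this assay, in either direction. The expected step that the limit leaves unreadable from compound 3 to compound 4 stays within the usual scatter. Compound 4 is estimated at 110 ug/mL, with an expected range from 60 ug/mL to 200 ug/mL, and it will most likely be reported only as a limit.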

Compound 4, half-maximal inhibitory concentration: 15.2 ug/mL
Beside the measured number, compound 4's estimate is 7.2-fold (0.86 log units) above it; measured number outside the range, below it.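

In this assay, this aromatic carbon para to a large group proves able to bring a reading off the limit: methyl in place of fluoro is an at least 6.5-fold lower number from compound 3 to compound 4 (0.81 log units; beyond the scatter), methyl in place of methoxy is an at least 6.5-fold lower number from compound 2 to compound 4 (0.81 log units; beyond the scatter), and methyl in place of methylsulfanyl is an at least 6.5-fold lower number from compound 1 to compound 4 (0.81 log units; beyond the scatter). The steps among the three earlier compounds cannot be read, so they could not show what compound 4 shows, with its 15.2 ug/mL: the group at this carbon can change the reading, and a change of a single heavy atom, from fluoro to methyl, is enough. The true size of each new step stays unknown, since one end of each is a limit of the assay and not a number: the limit of > 100 ug/mL in this assay, at which 3 of the 4 values shown sit.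

With methyl the only group here that gives a number, the compounds shown leave open whether the effect is particular to methyl or would also appear with an ethyl, a chloro or a longer chain at this carbon. They also leave open how an amine or a carboxylic acid at the same place would read in this assay.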